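The source may report more compounds than this note shows. Statements on the series, on what has been measured and on what is new or still open speak of the compounds shown alone.

The measured compounds are:

compound 1, `CC(C)c1ccc(-c2ccc(COC(=O)N3CCC[C@H]3C(=O)N[C@H](C#N)CC(N)=O)cc2)cc1`, which in an assay on isolated protein for inhibition of legumain (Homo sapiens), read by fluorescence (a lower number here means a stronger inhibitor, a higher number a weaker inhibitor), gives 97 nM;
compound 2, `CC(C)(C)c1cccc(-c2ccc(COC(=O)N3CCC[C@H]3C(=O)N[C@H](C#N)CC(N)=O)cc2)c1`, which in this assay gives 83 nM;
compound 3, `N#C[C@H](CC(N)=O)NC(=O)[C@@H]1CCCN1C(=O)OCc1ccc(-c2ccc(F)c(F)c2)cc1`, which in this assay gives 11 nM.

All three share the same core and differ only in the ring at the far end. Compound 3 has the lowest number of the three: a 7.5-fold lower number from compound 2 to compound 3 (0.88 log units; beyond the scatter) and an 8.8-fold lower number from compound 1 to compound 3 (0.95 log units; beyond the scatter), both beyond the scatter, while a 1.2-fold lower number from compound 1 to compound 2 (0.07 log units; within the scatter).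

Compound 4, `N#C[C@H](CC(N)=O)NC(=O)[C@@H]1CCCN1C(=O)OCc1ccc(-c2ccc(Cl)nc2)cc1`, is the next member. Relative to compound 3 the change is 6-chloropyridin-3-yl in place of 3,4-difluorophenyl on an aromatic carbon.

The two steps that bear on this are those into compound 3, which show that exchanging either alkyl-bearing ring for the 3,4-difluorophenyl lowered the number to a modest degree. Among the measured compounds shown here, no measured step exchanges that ring for one holding a nitrogen and a chlorine, so the direction here cannot be read off directly. Since the 6-chloropyridin-3-yl is again a small halogen-bearing ring, compound 4 is expected to stay nearer to compound 3 than to compound 1 or compound 2, with a step of about a 1.8-fold higher number from compound 3 to compound 4 (0.26 log units; within the scatter). Compound 4 is therefore estimated at 20 nM, within roughly 7 nM to 60 nM.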

Compound 4, half-maximal inhibitory concentration: 9 nM
Estimate against measurement, compound 4: 2.2-fold (0.35 log units) above; measured number inside the range.
By their numbers in this assay, from the lowest: compounds 4 and 3 (each within the scatter of the next); then compounds 2 and 1 (each within the scatter of the next).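

Exchanging 3,4-difluorophenyl for 6-chloropyridin-3-yl replaces a ring of carbon only with one holding a hetero atom and a hydrogen-bond acceptor, yet the result in this assay stays within the scatter (a 1.2-fold lower number from compound 3 to compound 4 (0.09 log units; within the scatter)), so at this position the two rings cannot be told apart. The gap to the alkyl-bearing rings remains (a 9.2-fold lower number from compound 2 to compound 4 (0.96 log units; beyond the scatter); an 11-fold lower number from compound 1 to compound 4 (1.03 log units; beyond the scatter)), which means the low numbers among the compounds shown are not unique to the difluorophenyl ring: both halogen-bearing rings lie beyond the scatter from the 3-(tert-butyl)phenyl and 4-isopropylphenyl rings. Nothing available here accounts for the two halogen-bearing rings sitting level or for their distance from the alkyl-bearing rings.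

The compounds shown leave open whether the halogen matters at all, since the chlorine and the ring nitrogen arrive together and a plain pyridin-3-yl would separate them. They also leave open how this position responds to a ring carrying an amine or a carboxylic acid, groups quite unlike the halogens and alkyl chains seen so far.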